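Dichlorophenyl on the aromatic nitrogen: compound 3 expected

This account rests on a few compounds, and the source may have more. Where it says the series, first, only, none or still open, it means among the compounds named here.

Going by the values given here, in a functional assay on A549 cells (Homo sapiens) for antiproliferative activity, read by MTT assay, with a stated time of 48 h (on this read-out lower numbers stand for stronger inhibition and higher numbers for weaker inhibition), compound 2 `Cc1cc(C)cc(-n2nncc2CN2C(=O)C3(C(C#N)=C(N)Oc4c(N)cc5nc6ccccc6nc5c43)c3ccccc32)c1` gives 31200 nM, the higher of the two numbers so far. Its nearest neighbour, compound 1 `N#CC1=C(N)Oc2c(N)cc3nc4ccccc4nc3c2C12C(=O)N(Cc1cnnn1-c1ccccc1Cl)c1ccccc12`, gives 29800 nM in this assay, and the step of a 1.0-fold higher number from compound 1 to compound 2 (0.02 log units; within the scatter) lies within the scatter. Compound 3 `N#CC1=C(N)Oc2c(N)cc3nc4ccccc4nc3c2C12C(=O)N(Cc1cnnn1-c1cc(Cl)ccc1Cl)c1ccccc12` differs from compound 2 by 2,5-dichlorophenyl in place of 3,5-dimethylphenyl on an aromatic nitrogen. Among the compounds with values here, only that one step bears on a change of the group on the aromatic nitrogen, and it was within the scatter, so no shift beyond the scatter is expected. Compound 3 is therefore estimated at 30000 nM, with a range of 15000 nM to 60000 nM. The expected step is a 1.0-fold lower number from compound 2 to compound 3 (0.02 log units; within the scatter).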

Compound 3, half-maximal inhibitory concentration: 10900 nM
Compound 3: the middle estimate sits 2.8-fold (0.44 log units) above what was measured; the measured number lies below the stated range.
By their numbers in this assay, from the lowest: compound 3; then compounds 1 and 2 (each within the scatter of the next).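

In this assay, going by these compounds alone, the group on this aromatic nitrogen proved able to move the number: 2,5-dichlorophenyl in place of 3,5-dimethylphenyl gave a 2.9-fold lower number from compound 2 to compound 3 (0.46 log units; beyond the scatter) and is the first change here to exceed the scatter. Chloro in place of hydrogen on an aromatic carbon of the phenyl ring gave a 2.7-fold lower number from compound 1 to compound 3 (0.44 log units; beyond the scatter) and shows that this single added atom is enough for a shift of this size. No measurement shown here explains the shift. As far as these compounds go, whether a methoxy group or an amine on this phenyl ring would lower the number further remains open, as does whether a second chloro elsewhere on the ring would match compound 3.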